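Swapping Cyclohexyl for Phenoxymethyl on the Amide Carbonyl

This account rests on a few compounds, and the source may have more. Where it says the series, first, only, none or still open, it means among the compounds named here.

Compound 1 `O=C(Nc1nnc(-c2cccc(O)c2O)s1)c1ccccc1`: 22300 nM in a functional assay, with a stated time of 30 min, in the absence of a further agent; on this read-out lower numbers stand for stronger inhibition and higher numbers for weaker inhibition
Compound 2 `O=C(Nc1nnc(-c2cccc(O)c2O)s1)C1CCCCC1`: 19900 nM in this assay

Within the data shown here, the one measured step, a 1.1-fold lower number from compound 1 to compound 2 (0.05 log units; within the scatter), lies within the scatter. Compound 2 therefore stands lowest of the two numbers shown, with compound 1 nearest and within the scatter of it.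

Compound 3 `O=C(COc1ccccc1)Nc1nnc(-c2cccc(O)c2O)s1` differs from compound 2 by phenoxymethyl in place of cyclohexyl on a carbonyl carbon. Among the measured compounds shown here, the only step that bears on this, a 1.1-fold lower number from compound 1 to compound 2 (0.05 log units; within the scatter), was within the scatter, so no step beyond the scatter is expected here. Compound 3 is expected to give 20000 nM (range 7000 nM to 60000 nM). That estimate means a 1.0-fold higher number from compound 2 to compound 3 (0.00 log units; within the scatter), a step expected to stay within the scatter.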

Compound 3, half-maximal inhibitory concentration: 16600 nM
Compound 3: the middle estimate sits 1.2-fold (0.08 log units) above what was measured; measured number inside the range.
By their numbers in this assay, from the lowest: compounds 3, 2 and 1 (each within the scatter of the next).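

Phenoxymethyl brings an oxygen and a hydrogen-bond acceptor that cyclohexyl does not have, yet in this assay replacing cyclohexyl gives a 1.2-fold lower number from compound 2 to compound 3 (0.08 log units; within the scatter). Replacing phenyl with phenoxymethyl likewise gives a 1.3-fold lower number from compound 1 to compound 3 (0.13 log units; within the scatter), so on this carbonyl carbon three different groups, including one with an oxygen, now sit within the scatter of one another. Nothing available explains this flat result.

The compounds shown leave open whether an amine or a carboxylic acid on this carbonyl carbon would give a step beyond the scatter. The same question remains for a longer chain.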